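Fluoro in place of nitro: notes on compound 4

This account rests on a few compounds, and the source may have more. Where it says the series, first, only, none or still open, it means among the compounds named here.

Measured in a functional assay on MGC-803 cells (Homo sapiens) for antiproliferative activity, read by MTT assay, with a stated time of 48 h; on this read-out lower numbers stand for stronger inhibition and higher numbers for weaker inhibition:
- compound 1 `COc1ccc(CN(C(=O)CSc2nc3ccccc3s2)c2cc(OC)c(OC)c(OC)c2)cc1[N+](=O)[O-]` gives 682 nM
- compound 2 `COc1ccc(CN(C(=O)CSc2nc3cc(Cl)ccc3s2)c2cc(OC)c(OC)c(OC)c2)cc1O` gives 85 nM
- compound 3 `COc1ccc(CN(C(=O)CSc2nc3c(C)cccc3s2)c2cc(OC)c(OC)c(OC)c2)cc1O` gives 493 nM

Compound 1 at 682 nM cannot be separated from compound 3 at 493 nM, and both stand above compound 2 at 85 nM.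

The next compound, compound 4 `COc1ccc(CN(C(=O)CSc2nc3ccccc3s2)c2cc(OC)c(OC)c(OC)c2)cc1F`, differs from compound 1 at one place: fluoro in place of nitro on an aromatic carbon, ortho to a methoxy group and meta to a large group (fluoro in place of nitro on an aromatic carbon).

Within the data shown here, the only measured step, a 5.8-fold higher number from compound 2 to compound 3 (0.76 log units; beyond the scatter), lies elsewhere in the molecule, on a sulfur, and it is modest. Among the measured compounds shown here, no measured step touches the place of this change, so the data fix no direction for it. That step serves only as a rough guide to size. A change no larger than it is expected in this assay, quite possibly within the scatter. For the measured compounds named here, a slight lean to a lower number is expected, since compound 1 stands at 682 nM, among the higher values so far.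

The estimated step is a 1.7-fold lower number from compound 1 to compound 4 (0.23 log units; within the scatter).

For compound 4 the estimate is 400 nM, with an expected range from 120 nM to 1400 nM.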

Compound 4, half-maximal inhibitory concentration: 416 nM
Compound 4: the middle estimate sits 1.0-fold (0.02 log units) below what was measured; measured number inside the range.
By their numbers in this assay, from the lowest: compound 2; then compounds 4, 3 and 1 (each within the scatter of the next).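

In this assay, this position, an aromatic carbon ortho to a methoxy group and meta to a large group, now has its first direct reading (a 1.6-fold lower number from compound 1 to compound 4 (0.21 log units; within the scatter)), which lies within the scatter. Going from the 4-methoxy-3-nitrobenzyl group to the 3-fluoro-4-methoxybenzyl group replaces three heavy atoms and two hydrogen-bond acceptors with one heavy atom and no acceptor, yet compound 1 and compound 4 cannot be separated, so in this pair the nitro group is not required to hold the number at this level. No measurement on these two groups is available that would account for this result.

Open, going by these compounds, is how this position responds to groups other than these two: an amine, a carboxylic acid or a nitrile on the same aromatic carbon would show whether the level holds across more varied substituents. Also open, on these data alone, is whether the nitro and fluoro compounds would remain inseparable with the 5-chloro-1,3-benzothiazol-2-yl group of compound 2 on the sulfur.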